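This account rests on a few compounds, and the source may have more. Where it says the series, first, only, none or still open, it means among the compounds named here.

Compound 2 `Cc1cc(C)cc(Cn2c(SCC(=O)Nc3ccccc3Br)nc3ccc(Cl)cc32)c1` is the starting point of this step. In an ADME assay on MT4 cells (Homo sapiens) for cytotoxicity (a higher number here means that more compound is tolerated, a lower number that less compound is tolerated), compound 2 gives 174000 nM, the highest of the two plain numbers shown. Its nearest neighbour is compound 3 `Cc1cc(C)cc(S(=O)(=O)n2c(SCC(=O)Nc3ccccc3Br)nc3ccc(Cl)cc32)c1`, which in this assay gives 145000 nM; the step of a 1.2-fold lower number from compound 2 to compound 3 (0.08 log units; within the scatter) is within the scatter. Compound 1 `Cc1cc(C)cc(Cn2c(SCC(=O)Nc3ccccc3Br)nc3ccccc32)c1` reaches only a limit in this assay, namely >= 143000 nM. The step that the limit leaves unreadable from compound 1 to compound 2 therefore cannot be sized. Compound 4 `Cc1cc(C)cc(Cn2c(SCC(=O)Nc3ccccc3[N+](=O)[O-])nc3ccc(Cl)cc32)c1` differs from compound 2 in one place: nitro in place of bromo on an aromatic carbon. Among the measured compounds shown here, no measured step touches this part of the molecule; the one readable step stayed within the scatter, and the other is hidden by a limit. The step of a 1.1-fold lower number from compound 2 to compound 4 (0.04 log units; within the scatter) is therefore expected to stay within the scatter. Compound 4 is estimated at 160000 nM, between 80000 nM and 320000 nM.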

Compound 4, half-maximal cytotoxic concentration: 131000 nM
Estimate against measurement, compound 4: 1.2-fold (0.09 log units) above, and the stated range covers the measured number.
By their numbers in this assay, from the lowest: compounds 4, 3 and 2 (each within the scatter of the next).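

Earlier steps changed other parts of the molecule; this one changes the 2-bromophenyl end, and in this assay it is a 1.3-fold lower number from compound 2 to compound 4 (0.12 log units; within the scatter). So at this aromatic carbon, ortho to a large group, nitro and bromo cannot be told apart in this read-out, even though nitro brings more heavy atoms and hydrogen-bond acceptors. From the compounds shown here alone, whether an amine or a carboxylic acid on this carbon would give a step beyond the scatter stays open. The step between compound 1 and compound 2 also cannot be read: the limit of >= 143000 nM in this assay, at which 1 of the 4 values shown sits.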